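The source may report more compounds than this note shows. Statements on the series, on what has been measured and on what is new or still open speak of the compounds shown alone.

Compound 1 `Nc1ccccc1NC(=O)c1ccc(CSC(=S)N2CCc3cc(Cl)ccc32)cc1` gives 40.1% in a functional assay on HeLa cells (Homo sapiens) for antiproliferative activity, read by CCK-8 assay, with a stated time of 72 h, tested at 2 uM (a lower number here means a weaker effect, a higher number a stronger effect of the compound at the concentration tested), the second highest of the three numbers measured. Compound 3 `Nc1ccccc1NC(=O)c1ccc(CSC(=S)N2CCCC2)cc1` gives 51.3%, and compound 2 `CN(Cc1cccnc1)C(=S)SCc1ccc(C(=O)Nc2ccccc2N)cc1` gives 16.4%; the steps are a number 11.2 percentage points higher from compound 1 to compound 3 (beyond the scatter) and a number 23.7 percentage points lower from compound 1 to compound 2 (beyond the scatter). Compound 4 `COC(=O)c1ccc2c(c1)CCN2C(=S)SCc1ccc(C(=O)Nc2ccccc2N)cc1` is not yet measured. It differs from compound 1 in one place: methoxycarbonyl in place of chloro on an aromatic carbon. Both measured steps swap the whole group on the thiocarbonyl carbon, whereas this change only exchanges a substituent on the aromatic carbon of the fused two-ring system, so they bear on it only loosely and were modest in size. A step no larger than the scatter is therefore expected, so compound 4 is estimated at 36%, within 18% to 54%, a step of a number 4.1 percentage points lower from compound 1 to compound 4 (within the scatter).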

Compound 4, a percentage reported as inhibition, at one concentration (the size of the read-out at that concentration, not a potency): 45.3%
Compound 4: the middle estimate sits 9.3 percentage points below what was measured, within the range that was stated.
By their numbers in this assay, from the lowest: compound 2; then compounds 1, 4 and 3 (each within the scatter of the next, the first and the last beyond it).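

In this assay, methoxycarbonyl in place of chloro on this aromatic carbon gives a number 5.2 percentage points higher from compound 1 to compound 4 (within the scatter) and so stays within the scatter, even though 4 heavy atoms replace 1. Unlike the earlier swaps of the whole group on the thiocarbonyl carbon, this step leaves that group's fused two-ring system in place and shows that this position can carry a larger group with 2 hydrogen-bond acceptors. Nothing available explains this result. The compounds shown leave open whether a carboxylic acid or an amine on this carbon would give a similar number. They also leave open how a longer ester chain would compare.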